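This account rests on a few compounds, and the source may have more. Where it says the series, first, only, none or still open, it means among the compounds named here.

Measured so far: compound 3 `CC(C)c1onc(-c2c(Cl)cccc2Cl)c1COc1ccc(NCc2ccc(C(=O)O)cc2)c(C(F)(F)F)n1` gives 398 nM in a functional assay on HEK293 cells for agonist activity at Bile acid receptor (Homo sapiens); a higher number here means that more compound is needed for the effect, a lower number that less compound is needed; compound 1 `CC(C)c1onc(-c2c(Cl)cccc2Cl)c1COc1ccc(NC(=O)c2ccc(C(=O)O)cc2)c(C(F)(F)F)n1` gives 474 nM; compound 2 `CC(C)c1onc(-c2c(Cl)cccc2Cl)c1COc1ccc(N(C)C(=O)c2cccc(C(=O)O)c2)c(C(F)(F)F)n1` gives 571 nM.

Compound 3 has the lowest of the three numbers, but its neighbours lie within the scatter of it. Compound 4 `CC(C)c1onc(-c2c(Cl)cccc2Cl)c1COc1ccc(N(C)Cc2cccc(C(=O)O)c2)c(C(F)(F)F)n1` differs from compound 3 by (3-carboxybenzyl)(methyl)amino in place of (4-carboxybenzyl)amino on an aromatic carbon. Going by the values given here, one measured step bears on this position: a 1.2-fold lower number from compound 1 to compound 3 (0.08 log units; within the scatter). Among the compounds with values here, no step is recorded between compound 1 and compound 2, which carries the methylated nitrogen and the rearranged carboxy group on the amide side; their two values sit close together. Both observations point to the same reading, so for compound 4 a step of a 1.3-fold higher number from compound 3 to compound 4 (0.12 log units; within the scatter) is expected, none beyond the scatter. Compound 4 is therefore estimated at 520 nM, within 250 nM to 1100 nM.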

Compound 4, half-maximal effective concentration: 80 nM
Beside the measured number, compound 4's estimate is 6.5-fold (0.81 log units) above it, outside the stated range (below it).
By their numbers in this assay, from the lowest: compound 4; then compounds 3, 1 and 2 (each within the scatter of the next).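

Going by these compounds alone, exchanging (4-carboxybenzyl)amino for (3-carboxybenzyl)(methyl)amino is the first change at this position to move the number beyond the scatter, with a 5.0-fold lower number from compound 3 to compound 4 (0.70 log units; beyond the scatter), and compound 4 also stands clear of the amide compound 1, with a 5.9-fold lower number from compound 1 to compound 4 (0.77 log units; beyond the scatter). Putting 3-carboxybenzyl in place of (3-carboxyphenyl)carbonyl gives a 7.1-fold lower number from compound 2 to compound 4 (0.85 log units; beyond the scatter), whereas the matching exchange in the 4-carboxy series, a 1.2-fold lower number from compound 1 to compound 3 (0.08 log units; within the scatter), stays within the scatter, so the effect of losing the carbonyl depends on the rest of the group. No available evidence accounts for this result.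

The compounds shown do not separate the nitrogen methyl from the shift of the carboxy group within the step to compound 4. On these data alone, whether an ethyl on that nitrogen or a tetrazole in place of the carboxylic acid would lower the number further also remains open.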